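Swapping one aromatic group in a growth-inhibiting series

A few compounds are considered here, and "the series" means these few. Any claim that something is new, unique, unknown or untested is made for them only; others in the source may bear on it.

Compound 1 `Cc1ccc(S/C(=C/c2c[nH]c3ccccc23)C(=O)c2ccc(Br)cc2)cc1` gives 10000 nM
Compound 2 `Cc1ccc(C)c(/C=C(\C(=O)c2ccc(Br)cc2)S(=O)(=O)Cc2ccc(F)cc2)c1` gives 1000 nM
Compound 3 `COc1ccsc1/C=C(\C(=O)c1ccc(Br)cc1)S(=O)(=O)Cc1ccc(Cl)cc1` gives 50000 nM

In a functional assay on DU-145 cells (Homo sapiens) for inhibition, read by trypan blue exclusion, with a stated time of 96 h (a higher number here means a weaker inhibitor of growth, a lower number a stronger inhibitor of growth), compound 2 gives the lowest number of the three at 1000 nM and so is the strongest inhibitor of growth here. Its gaps to compound 1 and compound 3 both lie beyond the usual scatter. Among the measured compounds shown here, no two measured compounds differ in one place only, so no measured step shows what a single change does.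

Compound 4 `CN(C)c1ccc(/C=C(\C(=O)c2ccc(Br)cc2)S(=O)(=O)Cc2ccc(F)cc2)cc1` differs from compound 2 in one group: 4-(dimethylamino)phenyl in place of 2,5-dimethylphenyl on a double-bonded chain carbon bound to a double-bonded chain carbon and in short 4-(dimethylamino)phenyl takes the place of 2,5-dimethylphenyl on a double-bonded chain carbon bound to a double-bonded chain carbon.

The measured compounds carry different groups on that carbon, and their values run from compound 2 at 1000 nM to compound 3 at 50000 nM even though they differ elsewhere too. Compound 2 at 1000 nM already sits at the low end of that spread, so a rise in the number is the likelier outcome. In this assay the expected step runs a 3.0-fold higher number from compound 2 to compound 4 (0.48 log units; beyond the scatter) toward a weaker inhibitor of growth, though this rests on very little data. Compound 4 is estimated at 3000 nM with a range of 400 nM to 20000 nM as the expected spread.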

Compound 4, concentration for 50% growth inhibition: 50000 nM
Compound 4: the middle estimate sits 17-fold (1.22 log units) below what was measured, and the stated range ends below it.
By their numbers in this assay, from the lowest: compound 2; then compound 1; then compounds 3 and 4 (each within the scatter of the next).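

In this assay, putting 4-(dimethylamino)phenyl in place of 2,5-dimethylphenyl on a double-bonded chain carbon bound to a double-bonded chain carbon gives a 50-fold higher number from compound 2 to compound 4 (1.70 log units; beyond the scatter), a large step beyond the scatter. Among the compounds shown here, this is the first single change measured, and it shows that this position is sensitive to which aromatic group it carries: with the rest of the molecule held the same, this swap alone turns compound 2 into a much weaker inhibitor of growth. The entering group adds a nitrogen and a hydrogen-bond acceptor, but nothing measured here connects either feature to the loss, so the reason for the step remains unknown.

This one pair cannot separate the loss of the two methyl groups on the ring from the arrival of the dimethylamino group, since both happen in the same swap. From the compounds shown here alone, how a plain phenyl or a 4-methoxyphenyl group would behave on this carbon remains open, and those results would help show which part of the change matters.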